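A few compounds are considered here, and "the series" means these few. Any claim that something is new, unique, unknown or untested is made for them only; others in the source may bear on it.

Three compounds in this set share one core. In a functional assay for activation of Alpha-1A adrenergic receptor (Homo sapiens), read by calcium flux (on this read-out higher numbers stand for an effect only at larger amounts of compound and lower numbers for an effect already at smaller amounts), compound 1 `CCN(CC)C(=O)c1ccccc1OCC1=NCCN1` is known only by a limit of the assay, < 5020 nM. Compound 2 `Cc1cccnc1-c1ccccc1OCC1=NCCN1` likewise reaches only a limit in this assay, < 100000 nM. For the measured compounds named here, compound 3 `c1ccc(-c2cnccn2)c(OCC2=NCCN2)c1` is the single compound with a number: in this assay compound 3 gives 2.51 nM. Compound 4 `c1ccc(-c2ccsc2)c(OCC2=NCCN2)c1` has not yet been measured; it differs from compound 3 by thiophen-3-yl in place of pyrazin-2-yl on an aromatic carbon. Going by the values given here, no measured step covers an exchange of this kind, so the expectation rests on compound 3 alone. A modest weakening, somewhat beyond the scatter, is expected, giving an estimated step of a 4.0-fold higher number from compound 3 to compound 4 (0.60 log units; beyond the scatter). Compound 4 is therefore expected to give about 10 nM in this assay, with a likely range from 2 nM to 60 nM.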

Compound 4, half-maximal effective concentration: 0.251 nM
Beside the measured number, compound 4's estimate is 40-fold (1.60 log units) above it, and the stated range ends above it.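

Exchanging pyrazin-2-yl for thiophen-3-yl on this aromatic carbon gives a 10-fold lower number from compound 3 to compound 4 (1.00 log units; beyond the scatter) in this assay. Until now only compound 3 carried a number, so no exchange at this position could be read; this one shows that the five-membered aromatic ring with sulfur gives the lower number of the two. Nothing shown here gives a reason for this step.

This single exchange does not separate ring size from ring atoms. On these data alone, how a plain phenyl, a thiophen-2-yl or a ring bearing an amine would read at this position stays open.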